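The source may report more compounds than this note shows. Statements on the series, on what has been measured and on what is new or still open speak of the compounds shown alone.

Measured so far:
- Compound 1 `Cc1ccc(C(=O)N/N=C/c2ccccc2)c(O)c1`: 53900 nM
- Compound 2 `Cc1ccc(C(=O)N/N=C/c2ccc(N(C)C)cc2)c(O)c1`: > 100000 nM

In a functional assay (Mus musculus, strain BALB/C) for inhibition, read by MTT assay, with stated times of 24 h and 72 h (on this read-out lower numbers stand for stronger inhibition and higher numbers for weaker inhibition), compound 1 gives 53900 nM. For compound 2 the value > 100000 nM is a limit of this assay, not a number, and it sits at the limit noted in the limit of > 100000 nM in this assay, at which 1 of the 2 values shown sits. Going by the values given here, the measured step of an at least 1.8-fold higher number from compound 1 to compound 2 (0.26 log units; that floor lies within the scatter) concerns dimethylamino in place of hydrogen on an aromatic carbon; no measured step matches the change to compound 3 `Cc1ccc(C(=O)N/N=C/c2ccc([N+](=O)[O-])cc2)c(O)c1`, which is nitro in place of dimethylamino on an aromatic carbon. With only a limit for compound 2 and a single value for compound 1 to lean on, compound 3 is expected near compound 1, at an estimated 60000 nM (range 15000 nM to 200000 nM), a step of an at least 1.6-fold lower number from compound 2 to compound 3 (0.22 log units; that floor lies within the scatter) that is expected but uncertain.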

Compound 3, half-maximal inhibitory concentration: 24300 nM
The estimate for compound 3 lay 2.5-fold (0.39 log units) above the measured number; the range from low to high includes it.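

In this assay nitro in place of hydrogen gives a 2.2-fold lower number from compound 1 to compound 3 (0.35 log units; beyond the scatter) on the aromatic carbon para to a large group, so a change at this position can move the number beyond the scatter, which the earlier step did not show. Nitro in place of dimethylamino gives an at least 4.1-fold lower number from compound 2 to compound 3 (0.61 log units; beyond the scatter) as a floor, so these two groups clearly read apart here. Compound 2 holds only a limit of the assay, not a number: the limit of > 100000 nM in this assay, at which 1 of the 3 values shown sits.

One nitro result sets no trend, and these compounds give no cause for it. As far as these compounds go, how a primary amine, a nitrile or a carboxylic acid would read at this position stays open.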